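The source may hold more compounds than are shown below. What is called first, only, known or untested is meant among the compounds shown, and "the series" means these compounds.

Measured compounds:
- compound 1 `Cc1ccccc1-n1cc(-c2ccccc2NS(=O)(=O)c2c[nH]c(=O)[nH]c2=O)nn1` — 9570 nM in a functional assay on SGC-7901 cells (Homo sapiens) for antiproliferative activity, read by MTT assay, with a stated time of 24 h; on this read-out higher numbers stand for weaker inhibition and lower numbers for stronger inhibition
- compound 2 `O=c1[nH]cc(S(=O)(=O)Nc2ccccc2-c2cn(-c3cccc(F)c3)nn2)c(=O)[nH]1` — > 20000 nM in this assay
- compound 3 `O=c1[nH]cc(S(=O)(=O)Nc2ccccc2-c2cn(-c3ccc(F)cc3)nn2)c(=O)[nH]1` — > 20000 nM in this assay

The value of compound 2 is a limit of the assay, not a number. The value of compound 3 is likewise a limit, and compound 3 thus stands at the limit of > 20000 nM in this assay, at which 2 of the 3 values shown sit, with no readable number of its own. For the measured compounds named here, the two readable steps run from the one numbered compound: an at least 2.0-fold higher number from compound 1 to compound 2 (0.32 log units; beyond the scatter) and an at least 2.0-fold higher number from compound 1 to compound 3 (0.32 log units; beyond the scatter); the pair of compound 2 and compound 3 gives a step that the two limits leave unreadable from compound 2 to compound 3.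

Compound 4 `O=c1[nH]cc(S(=O)(=O)Nc2ccccc2-c2cn(-c3ccc(Cl)cc3)nn2)c(=O)[nH]1` differs from compound 3 by chloro in place of fluoro on an aromatic carbon. Going by the values given here, none of the measured steps touches a halogen exchange on the ring attached to the aromatic nitrogen; the only steps seen replace the whole substituent pattern of that ring, and both end at the limit. The expectation for compound 4 is therefore a step of about a number no higher from compound 3 to compound 4 (the limit leaves the size open), meaning no movement beyond the scatter away from the limit. Compound 4 is estimated at 20000 nM, within 8000 nM to 45000 nM, with a fair chance that again only a limit is reported.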

Compound 4, half-maximal inhibitory concentration: 2700 nM
Compound 4: middle estimate off by 7.4-fold (0.87 log units), on the high side; the whole stated range lies above it.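

In this assay, exchanging one halogen for another at this place gives an at least 7.4-fold lower number from compound 3 to compound 4 (0.86 log units; beyond the scatter), so the outcome depends on which halogen is present and not only on where the ring is substituted. The 4-chlorophenyl group also gives an at least 7.4-fold lower number from compound 2 to compound 4 (0.86 log units; beyond the scatter) and a 3.5-fold lower number from compound 1 to compound 4 (0.55 log units; beyond the scatter), making it better than the 2-methylphenyl group, the only earlier substituent with a readable number. Compound 2 and compound 3 are limits of the assay and not numbers, so the true size of the first two steps stays open: the limit of > 20000 nM in this assay, at which 2 of the 4 values shown sit.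

As far as these compounds go, whether the gain is specific to chloro or extends to other groups on this aromatic carbon remains open, and bromo, methoxy or an amine there would test this. It is also unknown whether chloro would give a similar gain on the ring of compound 1.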